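A few compounds are considered here, and "the series" means these few. Any claim that something is new, unique, unknown or untested is made for them only; others in the source may bear on it.

Compound 1, `CC(=O)O[C@@H]1[C@@H](OC(C)=O)[C@H](O)[C@@H](CO)O[C@H]1NC(=S)NNC(=O)Cn1cnc2c(N)ncnc21`, gives 94500 nM in a functional assay on PG cells (Homo sapiens) for cytotoxicity, read by MTT assay, with a stated time of 48 h; on this read-out higher numbers stand for an effect only at larger amounts of compound and lower numbers for an effect already at smaller amounts. Compound 2, `CC(=O)O[C@@H]1[C@@H](OC(C)=O)[C@@H](O)[C@@H](CO)O[C@H]1NC(=S)NNC(=O)Cn1cnc2c(N)ncnc21`, reaches only a limit of this assay, > 100000 nM.

Compound 2 thus stands at the top of the numbers shown, with a limit rather than a number. Going by the values given here, the one measured step, an at least 1.0-fold higher number from compound 1 to compound 2 (0.02 log units; that floor lies within the scatter), lies within the scatter, which sits with the fact that compounds 1 and 2 differ only in the configuration as drawn and with the limit of > 100000 nM in this assay, at which 1 of the 2 values shown sits. Compound 3, `CC(=O)O[C@@H]1[C@@H](OC(C)=O)[C@@H](O)CO[C@H]1NC(=S)NNC(=O)Cn1cnc2c(N)ncnc21`, differs from compound 2 by hydrogen in place of hydroxymethyl on a saturated ring carbon. Among the compounds with values here, no measured step concerns this change, so the expectation rests on the weakness of both measured compounds in this assay and on the chance that compound 3 too is reported only as a limit. The step of a number no higher from compound 2 to compound 3 (the limit leaves the size open) is expected to stay within the scatter, with no direction beyond it. Compound 3 is estimated at 100000 nM, in a range from 45000 nM to 220000 nM.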

Compound 3, half-maximal effective concentration: > 200000 nM
Compound 3 was reported as a limit (the forecaster's own chance of this, stated with the estimate: 60%); at least 2.0-fold (0.30 log units) between middle value and limit.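

Compound 2 and compound 3 are both reported only as limits in this assay, so the step between them cannot be read. The compounds shown leave open whether hydrogen in place of hydroxymethyl on a saturated ring carbon changes the read-out at all.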